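Shortening the allyl ether chain of compound 2 to a propargyl ether

This account rests on a few compounds, and the source may have more. Where it says the series, first, only, none or still open, it means among the compounds named here.

In an in vitro assay on HEK-tsA201 cells for antagonist activity at Neuronal acetylcholine receptor; alpha4/beta2 (Homo sapiens), read by fluorescence and calcium flux (on this read-out higher numbers stand for weaker inhibition and lower numbers for stronger inhibition), two compounds of the shared core have been measured so far. Compound 1 `C=CCOc1ccc(C(=O)Nc2cccc(C)n2)cc1` gives 6000 nM in this assay, while compound 2 `C=C(C)COc1ccc(C(=O)Nc2cccc(C)n2)cc1` gives 19600 nM. For the measured compounds named here, on these two numbers compound 2 stands highest, with compound 1 as its only neighbour; the step of a 3.3-fold higher number from compound 1 to compound 2 (0.51 log units; beyond the scatter) is the one measured step in the set.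

Compound 3 `C#CCOc1ccc(C(=O)Nc2cccc(C)n2)cc1` differs from compound 2 by ethynyl in place of 1-methylethenyl on a saturated chain carbon bound to an oxygen on an aromatic ring. This change removes the methyl whose introduction produced the step from compound 1 to compound 2 and at the same time turns the double bond into a triple bond. Only the first part of that change is covered by a measured step, so the expectation for compound 3 rests on compound 1, whose value of 6000 nM shows where the chain without the methyl stands, with an unknown contribution from the triple bond. Compound 3 is therefore expected to give a lower number than compound 2, the estimated step being a 3.0-fold lower number from compound 2 to compound 3 (0.48 log units; beyond the scatter). In this assay compound 3 is estimated at 6500 nM, with a range from 2500 nM to 17000 nM.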

Compound 3, half-maximal inhibitory concentration: 19400 nM
Beside the measured number, compound 3's estimate is 3.0-fold (0.47 log units) below it; measured number above the stated range.
By their numbers in this assay, from the lowest: compound 1; then compounds 3 and 2 (each within the scatter of the next).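

In this assay, ethynyl in place of 1-methylethenyl on a saturated chain carbon bound to an oxygen on an aromatic ring gives no readable difference (a 1.0-fold lower number from compound 2 to compound 3 (0.00 log units; within the scatter)), even though this change takes away the methyl that marked the step from compound 1 to compound 2 (a 3.3-fold higher number from compound 1 to compound 2 (0.51 log units; beyond the scatter)). The higher number therefore does not depend on that methyl, since ethynyl in place of vinyl, with no methyl involved, gives a step of similar size (a 3.2-fold higher number from compound 1 to compound 3 (0.51 log units; beyond the scatter)), and among these three chains only the vinyl-ended chain of compound 1 stands apart. Nothing available here explains why the two different replacements of that vinyl end arrive at numbers within the scatter of each other.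

As far as these compounds go, it remains open whether a saturated propyl chain, a longer chain ending in a triple bond, or a chain ending in an amine would stand with compound 1 or with compounds 2 and 3. From the compounds shown here alone, it is also open whether the same ordering of these ether chains would hold if another group took the place of the methyl on the amide side of the shared core.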